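The compounds below may be only part of what the source reports. "The series", "measured", "known", "first", "only" and "open" are said of these compounds alone.

In a physicochemical assay for lipophilicity (a lower number here means a more polar compound, a higher number a more lipophilic compound), compound 1 (`C=C1CC[C@@H]2[C@](C)(COC(C)=O)[C@H](OC(C)=O)CC[C@@]2(C)[C@@H]1C/C=C1\C=COC1=O`) reads 3.87 and sits within the scatter of compound 2 (`C=C1CC[C@@H]2[C@](C)(COC(C)=O)[C@H](OC(C)=O)CC[C@@]2(C)[C@@H]1/C=C/C1=CCOC1=O`) at 3.83 while compound 3 (`C=C1CC[C@@H]2[C@](C)(CO)[C@H](O)CC[C@@]2(C)[C@@H]1CCC1C(=O)OC[C@H]1O`) lies clearly lower at 2.54 on this scale. Compound 4 (`C=C1CC[C@@H]2[C@](C)(COC(C)=O)[C@H](OC(C)=O)CC[C@@]2(C)[C@@H]1CCC1C(=O)OC[C@H]1OC(C)=O`) is still unmeasured. Its change from compound 1 is a group of 11 heavy atoms (7 carbon, 4 oxygen; one five-membered non-aromatic ring with 1 hetero atom) in place of a group of 7 heavy atoms (5 carbon, 2 oxygen; one five-membered non-aromatic ring with 1 hetero atom), on a saturated chain carbon bound to a saturated ring carbon and the entering group is (4-acetoxy-2-oxooxolan-3-yl)methyl. Within the data shown here, the only single-place step measured (a number 0.04 log units lower from compound 1 to compound 2 (within the scatter)) exchanges groups of equal size and gives little guidance for a larger group. Among the measured compounds shown here, compound 3 at 2.54 marks the low end of the series so far. A moderate drop is expected (a number 0.47 log units lower from compound 1 to compound 4 (beyond the scatter)) and this remains an estimate. Compound 4 is expected at 3.4 within an estimated range (3 to 3.8).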

Compound 4, partition coefficient: 3.71
The estimate for compound 4 lay 0.31 log units below the measured number, and the stated range covers the measured number.
By their numbers in this assay, from the lowest: compound 3; then compounds 4, 2 and 1 (each within the scatter of the next).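

In this assay, the step to the larger (4-acetoxy-2-oxooxolan-3-yl)methyl group is a number 0.16 log units lower from compound 1 to compound 4 (within the scatter), so this saturated chain carbon bound to a saturated ring carbon has now taken a change in group size, not only the equal-sized exchange seen earlier. The entering group carries more oxygen atoms and hydrogen-bond acceptors than the group it replaces, yet the read-out stays within the scatter. No supporting data bear on this result. Still open, going by these compounds, is whether an amine or a carboxylic acid at this place would stay as close to compound 1, and what the acetoxy of the entering group contributes on its own.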